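Notes on the amide substituent of the series

This account rests on a few compounds, and the source may have more. Where it says the series, first, only, none or still open, it means among the compounds named here.

Compound 1 `NCCNc1cc(N2CCN(C(=O)C3(c4ccccc4)CCCC3)CC2)nc2ccccc12` carries a 1-phenylcyclopentyl group on the carbonyl carbon. In an ADME assay on HEp-2 cells (Homo sapiens) for cytotoxicity, read by CCK-8 assay, with a stated time of 6 days (a higher number here means that more compound is tolerated, a lower number that less compound is tolerated), compound 1 gives only a limit, > 100000 nM. Compound 3 `CCC(=O)N1CCN(c2cc(NCCN)c3ccccc3n2)CC1`, the propanoyl analog, likewise reaches only a limit in this assay, > 100000 nM. For the measured compounds named here, compound 2 `NCCNc1cc(N2CCN(c3ccccc3Cl)CC2)nc2ccccc12`, with 2-chlorophenyl on the amine nitrogen in the ring, is the one member with a number in this assay: 20800 nM. The step that the two limits leave unreadable from compound 1 to compound 3 is therefore not readable, while an at least 4.8-fold higher number from compound 2 to compound 3 (0.68 log units; beyond the scatter). Compound 4 `CC(=O)N1CCN(c2cc(NCCN)c3ccccc3n2)CC1` is unmeasured; it differs from compound 1 by methyl in place of 1-phenylcyclopentyl on a carbonyl carbon. Going by the values given here, the closest measured step, the one from compound 1 to compound 3, ends at a limit, and the limit of > 100000 nM in this assay, at which 2 of the 3 values shown sit, is where compound 3 also sits, so no readable step in this assay is expected from compound 1 to compound 4: a step that the limit leaves unreadable from compound 1 to compound 4. Compound 4 is expected to give 150000 nM in this assay, between 60000 nM and 400000 nM, most likely again reported only as a limit.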

Compound 4, half-maximal cytotoxic concentration: > 100000 nM
Compound 4: a limit, no number; the forecaster's own chance of this, stated with the estimate: 80%; the middle value lies beyond the limit too.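

Compound 4 also reaches only a limit in this assay, > 100000 nM. The steps among the three carbonyl-bearing compounds cannot be read, because each end of them sits at the same limit: the limit of > 100000 nM in this assay, at which 3 of the 4 values shown sit.

With acetyl in place of 2-chlorophenyl on the amine nitrogen in the ring, the series shows an at least 4.8-fold higher number from compound 2 to compound 4 (0.68 log units; beyond the scatter), so acetyl now stands with propanoyl on the higher side of that comparison.

The compounds shown give no number for any carbonyl-bearing member, so the size of the effect of the group on the carbonyl carbon stays open. Also open, on these data alone, is whether an unsubstituted phenyl on the amine nitrogen in the ring, or a carboxylic acid or a primary amine at the end of a longer chain on the carbonyl carbon, would give a number in this assay.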